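Dimethylamide in Place of Carboxylic Acid on a Macrocycle

The source may hold more compounds than are shown below. What is called first, only, known or untested is meant among the compounds shown, and "the series" means these compounds.

Compound 1, `CC(=O)O[C@]1(C)/C=C/C(=O)/C(CO)=C\C[C@](C)(CCC=C(C)C)/C=C/[C@H]1OC(=O)C=C(C)C`: 2010 nM
Compound 2, `CC(C)=CCC[C@]1(C)/C=C/[C@@H](OC(=O)C=C(C)C)[C@](C)(O)/C=C/C(=O)/C(C(=O)O)=C\C1`: > 10000 nM
Compound 3, `CC(C)=CCC[C@]1(C)/C=C/[C@@H](OC(=O)C=C(C)C)[C@](C)(O)/C=C/C(O)/C(C=O)=C\C1`: 1430 nM

The three measured compounds were tested in a functional assay on SW480 cells (Homo sapiens) for antiproliferative activity, read by MTT assay, with a stated time of 48 h; a higher number here means a weaker inhibitor, a lower number a stronger inhibitor. Compound 1 gives 2010 nM and compound 3 gives 1430 nM; these two values lie within the scatter of each other. For compound 2 the assay reports only a limit, > 10000 nM, and not a number. Compound 2 thus stands at the limit of > 10000 nM in this assay, at which 1 of the 3 values shown sits, the weakest position among the values shown.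

Compound 4, `CC(C)=CCC[C@]1(C)/C=C/[C@@H](OC(=O)C=C(C)C)[C@](C)(O)/C=C/C(=O)/C(C(=O)N(C)C)=C\C1`, has not yet been measured. It differs from compound 2 by dimethylamino in place of hydroxy on a carbonyl carbon.

Within the data shown here, no step between two measured compounds is known in this set, so the size of the step from compound 2 to compound 4 rests only on the limit at which compound 2 sits. Because compound 2 sits at the limit of > 10000 nM in this assay, at which 1 of the 3 values shown sits, the expected step of an at least 3.3-fold lower number from compound 2 to compound 4 (0.52 log units; beyond the scatter) is a gain in potency, probably beyond the scatter. Compound 4 is therefore estimated at 3000 nM, with a range from 800 nM to 10000 nM.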

Compound 4, half-maximal inhibitory concentration: 3300 nM
Compound 4: the middle estimate sits 1.1-fold (0.04 log units) below what was measured, and the stated range covers the measured number.
By their numbers in this assay, from the lowest: compounds 3, 1 and 4 (each within the scatter of the next, the first and the last beyond it). At a limit, above all of these: compound 2.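

In this assay, among these compounds, the change from carboxy to dimethylcarbamoyl, with dimethylamino in place of hydroxy on the carbonyl carbon, gives an at least 3.0-fold lower number from compound 2 to compound 4 (0.48 log units; beyond the scatter), the only step in this set that can be read. It shows that the hydroxy at this position, with its hydrogen-bond donor, is not required for a measurable number in this assay, since compound 4 gives 3300 nM. The step gives only a lower bound on the size of the change: the limit of > 10000 nM in this assay, at which 1 of the 4 values shown sits.

The compounds shown leave open whether this gain belongs to dimethylamino itself or would also follow with another group on the same carbonyl carbon, such as a primary amide, a methyl ester or a pyrrolidine amide. They also leave open the full size of the step.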